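From Cyclohexyl to 4-Chlorophenyl on the Sulfur Side Chain

The source may report more compounds than this note shows. Statements on the series, on what has been measured and on what is new or still open speak of the compounds shown alone.

In a functional assay on PC-9 cells (Homo sapiens) for inhibition, read by MTT assay, with a stated time of 72 h (a higher number here means a weaker inhibitor, a lower number a stronger inhibitor), compound 2 `Cc1cc(Nc2cc(-c3ccccc3)[nH]n2)n2nc(SCC3CCCCC3)nc2n1` gives only a limit, > 50000 nM, and not a number. Compound 4 `Cc1cc(Nc2cc(-c3ccccc3)[nH]n2)n2nc(SCc3ccc(Cl)cc3)nc2n1` differs from it by 4-chlorophenyl in place of cyclohexyl on a saturated chain carbon bound to a sulfur. Among the measured compounds shown here, no measured step covers this change directly. The closest compounds carry 4-bromobenzyl on the sulfur instead. Compound 1 `Cc1cc(Nc2cc(-c3cccs3)[nH]n2)n2nc(SCc3ccc(Br)cc3)nc2n1` gives 4890 nM, and compound 3 `Cc1cc(Nc2cc(C(C)(C)C)[nH]n2)n2nc(SCc3ccc(Br)cc3)nc2n1` gives 12400 nM. For the measured compounds named here, the one measured step, a 2.5-fold higher number from compound 1 to compound 3 (0.40 log units; beyond the scatter), is modest and lies beyond the scatter, but it concerns tert-butyl in place of thiophen-2-yl on an aromatic carbon, not the group on the sulfur. Going by the values given here, it suggests only that a change at that aromatic carbon need not move the number far. Compound 4 carries phenyl at that carbon, so a number in the region of compound 1 at 4890 nM and compound 3 at 12400 nM is expected. The expected step, toward a lower number, is an at least 6.2-fold lower number from compound 2 to compound 4 (0.79 log units; beyond the scatter). For compound 4 the estimated value is 8000 nM, with an expected range from 2500 nM to 25000 nM.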

Compound 4, half-maximal inhibitory concentration: 6710 nM
Estimate against measurement, compound 4: 1.2-fold (0.08 log units) above; the measured number falls inside the stated range.
By their numbers in this assay, from the lowest: compounds 1, 4 and 3 (each within the scatter of the next, the first and the last beyond it). At a limit, above all of these: compound 2.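

In this assay, 4-chlorophenyl in place of cyclohexyl on a saturated chain carbon bound to a sulfur gives an at least 7.4-fold lower number from compound 2 to compound 4 (0.87 log units; beyond the scatter). This is the first step shown that concerns the group on the sulfur, as the earlier step between compound 1 and compound 3 concerned only an aromatic carbon. It sets only a lower bound on the size of the change, because compound 2 stands at a limit and not at a number: the limit of > 50000 nM in this assay, at which 1 of the 4 values shown sits.

The compounds shown leave open whether the aromatic ring itself or its chlorine carries this step. Also open, as far as these compounds go, is how a plain benzyl, a 4-methoxybenzyl or a longer chain between the sulfur and the ring would read in this assay.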